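Swapping the naphthyl for a methoxyphenyl arm

A few compounds are considered here, and "the series" means these few. Any claim that something is new, unique, unknown or untested is made for them only; others in the source may bear on it.

Three compounds share one core, a bis(trifluoromethyl)phenyl sulfonamide linked through a short chain to an amine that carries an aromatic arm, and differ only in that arm. In a functional assay on Capan-2 cells (Homo sapiens) for inhibition, read by MTT assay, with a stated time of 72 h (a higher number here means a weaker inhibitor of growth, a lower number a stronger inhibitor of growth), compound 1 `O=S(=O)(NCCCNCc1ccccc1Cl)c1cc(C(F)(F)F)cc(C(F)(F)F)c1` gives 13000 nM, compound 2 `O=S(=O)(NCCCNCc1ccc(Br)cc1)c1cc(C(F)(F)F)cc(C(F)(F)F)c1` gives 2000 nM, and compound 3 `O=S(=O)(NCCCNCc1cccc2ccccc12)c1cc(C(F)(F)F)cc(C(F)(F)F)c1` gives 2700 nM. Compound 3 thus stands second highest of the three; its number sits close to that of compound 2, and the step from compound 1 is a 4.8-fold lower number from compound 1 to compound 3 (0.68 log units; beyond the scatter).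

Compound 4 `COc1cccc(CNCCCNS(=O)(=O)c2cc(C(F)(F)F)cc(C(F)(F)F)c2)c1` differs from compound 3 in one place: 3-methoxyphenyl in place of naphthalen-1-yl on a saturated chain carbon bound to an amine nitrogen. Going by the values given here, no measured step covers a methoxy-bearing arm, so the nearest guides are the two changes of the arm already seen, a 6.5-fold lower number from compound 1 to compound 2 (0.81 log units; beyond the scatter) and a 4.8-fold lower number from compound 1 to compound 3 (0.68 log units; beyond the scatter), both modest, while a 1.4-fold higher number from compound 2 to compound 3 (0.13 log units; within the scatter) shows that two quite different arms can give near-identical numbers. The whole spread across the three arms is no wider than the largest of these steps. A step of similar or smaller size is therefore expected in this assay for compound 4, most likely a slight move toward a higher number, a 1.5-fold higher number from compound 3 to compound 4 (0.17 log units; within the scatter), but a step that could also fall within the scatter. The estimate for compound 4 is 4000 nM, with a range from 1500 nM to 15000 nM.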

Compound 4, concentration for 50% growth inhibition: 6400 nM
Estimate against measurement, compound 4: 1.6-fold (0.20 log units) below, and the stated range covers the measured number.
By their numbers in this assay, from the lowest: compounds 2 and 3 (each within the scatter of the next); then compound 4; then compound 1.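

The arm position does not treat every aromatic group alike, a point the near-identical numbers of compound 2 and compound 3 could have hidden: in this assay the 3-methoxyphenyl arm gives a 2.4-fold higher number from compound 3 to compound 4 (0.37 log units; beyond the scatter) and also a 3.2-fold higher number from compound 2 to compound 4 (0.51 log units; beyond the scatter) and so falls out of step with both. It still does better than the 2-chlorophenyl arm, with a 2.0-fold lower number from compound 1 to compound 4 (0.31 log units; beyond the scatter) placing compound 4 in the middle ground, and since compound 2 and compound 4 each carry one aromatic ring yet differ beyond the scatter, the count of rings alone does not set the order of these arms. No measurement here explains why these arms rank as they do.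

The compounds shown leave open how much of the result belongs to the methoxy group and how much to the phenyl ring that carries it, a question that an unsubstituted phenyl arm, or a phenyl arm bearing a hydroxyl, a nitrile or a carboxylic acid, would help to settle. They also leave open how any of these arms would behave on a longer chain.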